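The source may report more compounds than this note shows. Statements on the series, on what has been measured and on what is new or still open speak of the compounds shown alone.

Compound 1 `Cc1ccc(-n2nc(-c3ccc(C(F)(F)F)cc3O)nc2-c2ccccc2O)cc1`: 94.1%
Compound 2 `Oc1cc(C(F)(F)F)ccc1-c1nc(-c2ccccc2O)n(-c2ccc(I)cc2)n1`: 94.4%

Within the data shown here, in a functional assay on PC-12 cells (Rattus norvegicus) for cytotoxicity, read by MTT assay, with stated times of 2 h and 24 h, tested at 5 uM (a higher number here means a stronger effect of the compound at the concentration tested, a lower number a weaker effect), compound 2 gives 94.4%, and it stands level with compound 1, the only other compound measured: the step of a number 0.3 percentage points higher from compound 1 to compound 2 (within the scatter) lies within the scatter. Compound 3 `Oc1cc(C(F)(F)F)ccc1-c1nc(-c2ccccc2O)n(-c2cccc(F)c2)n1` differs from compound 2 by 3-fluorophenyl in place of 4-iodophenyl on an aromatic nitrogen. Among the measured compounds shown here, the one measured step that bears on this, an exchange of a substituent on the same phenyl ring, was a number 0.3 percentage points higher from compound 1 to compound 2 (within the scatter), so no step beyond the scatter is expected here either, with an expected step of a number 2.4 percentage points lower from compound 2 to compound 3 (within the scatter). Compound 3 is therefore estimated at 92%, within a range from 80% to 99%.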

Compound 3, a percentage reported as activity, at one concentration (the size of the read-out at that concentration, not a potency): 87.7%
Estimate against measurement, compound 3: 4.3 percentage points above; measured number inside the range.
By their numbers in this assay, from the lowest: compounds 3, 1 and 2 (each within the scatter of the next).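

In this assay the exchange on the aromatic nitrogen now reaches a fluorine at another place on the phenyl ring: 3-fluorophenyl in place of 4-iodophenyl gives a number 6.7 percentage points lower from compound 2 to compound 3 (within the scatter) and in place of 4-methylphenyl gives a number 6.4 percentage points lower from compound 1 to compound 3 (within the scatter) at this one concentration. All three substituted phenyl groups at this position therefore lie within the scatter of one another. Nothing at hand accounts for these numbers. Still open, as far as these compounds go, is whether a group other than a substituted phenyl on this nitrogen, such as a pyridine ring, a benzyl group or a plain alkyl chain, would give a step beyond the scatter.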